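From Compound 1 to Compound 3: A Stability Estimate

The compounds below may be only part of what the source reports. "The series", "measured", "known", "first", "only" and "open" are said of these compounds alone.

Measured in an ADME assay on microsomes from liver (Homo sapiens) for metabolic stability, read by LC-MS, with a stated time of 10 min, tested at 0.5 uM; on this read-out higher numbers stand for a more stable compound and lower numbers for a less stable compound:
- compound 1 `CCN1CCN(CCCN(C[C@H]2Cc3ccccc3CN2)[C@H]2CCCc3cccnc32)CC1`: 59%
- compound 2 `c1cnc2c(c1)CN[C@@H](CN(CCCN1CCNCC1)[C@H]1CCCc3cccnc31)C2`: 79%

Of these two compounds, compound 1 stands lower, at 59%. The gap between it and compound 2, which stands at 79%, lies beyond the usual scatter of repeated measurements.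

The next compound to be measured is compound 3 `c1ccc2c(c1)CN[C@@H](CN(CCCCN1CCNCC1)[C@H]1CCCc3cccnc31)C2`. Going from compound 1 to compound 3, the structural change is (piperazin-1-yl)methyl in place of 4-ethylpiperazin-1-yl on a saturated chain carbon, three bonds along the chain from an amine nitrogen. Cut one bond further out, the same change reads 3-(4-ethylpiperazin-1-yl)propyl to 4-(piperazin-1-yl)butyl.

Among the measured compounds shown here, no measured pair shows this change on its own, so any forecast is uncertain. Compound 2, at 79%, is the only available reference higher on the scale. The expected step in this assay is a number 9 percentage points higher from compound 1 to compound 3 (within the scatter), a modest rise that may not clear the scatter. For compound 3 the estimated value is 68%, with an expected range of 50% to 85%.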

Compound 3, percent of the compound remaining: 82%
Beside the measured number, compound 3's estimate is 14 percentage points below it, and the stated range covers the measured number.
By their numbers in this assay, from the lowest: compound 1; then compounds 2 and 3 (each within the scatter of the next).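

In this assay, replacing the 3-(4-ethylpiperazin-1-yl)propyl group on the shared core with 4-(piperazin-1-yl)butyl gives a number 23 percentage points higher from compound 1 to compound 3 (beyond the scatter), so this part of the molecule can clearly affect the read-out. The change combines two edits, as the ethyl group leaves the piperazine ring and the chain grows from propyl to butyl, and the step cannot divide the rise between them. Nothing measured here explains the rise.

A 4-(4-ethylpiperazin-1-yl)butyl group on the same core would keep the ethyl group with the longer chain, and its number would help separate the two edits. Also open, as far as these compounds go, is how a still longer chain, such as 5-(piperazin-1-yl)pentyl, or a 4-methylpiperazin-1-yl group would score at this position.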